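This account rests on a few compounds, and the source may have more. Where it says the series, first, only, none or still open, it means among the compounds named here.

Measured compounds in the series:

- compound 1 `CCCCN1CCN(CCCCn2c3c(c4ccccc42)C(=O)c2c[n+]([O-])c4ccccc4c2C3=O)CC1`: 6900 nM
- compound 2 `CC1(C)O[C@@H](CO)[C@H](Cn2cc(Cn3c4c(c5ccccc53)C(=O)c3c[n+]([O-])c5ccccc5c3C4=O)nn2)O1`: 690 nM

Both numbers come from a functional assay on MCF7 cells (Homo sapiens) for cytotoxicity, read by MTT assay, with a stated time of 72 h; on this read-out higher numbers stand for weaker inhibition and lower numbers for stronger inhibition. Compound 1 stands at the highest of the two values; its nearest neighbour is compound 2, whose number in this assay is lower by a margin that lies beyond the usual scatter. The two compounds differ at more than one place, so nothing is drawn from that gap beyond what the two values show.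

Compound 3 `O=C1c2c[n+]([O-])c3ccccc3c2C(=O)c2c1c1ccccc1n2CCCN1CCC(O)CC1` is not yet measured. It departs from compound 1 by one change: 4-hydroxypiperidin-1-yl in place of (4-butylpiperazin-1-yl)methyl on a saturated chain carbon, three bonds along the chain from an aromatic nitrogen. The shared core and the attachment at the aromatic nitrogen are kept. Within the data shown here, no measured pair isolates this change, so the size of its effect in this assay is unknown from the data here.

For compound 3 the expectation is a number close to that of compound 1, with the step of a 1.4-fold lower number from compound 1 to compound 3 (0.14 log units; within the scatter) estimated to fall within the scatter, in either direction. Compound 3 is therefore estimated at 5000 nM, with a range from 1500 nM to 16000 nM in this assay.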

Compound 3, half-maximal inhibitory concentration: 190 nM
Estimate against measurement, compound 3: 26-fold (1.42 log units) above; measured number below the stated range.
By their numbers in this assay, from the lowest: compound 3; then compound 2; then compound 1.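

In this assay, among these compounds, this position on the chain is sensitive to the group it carries: 4-hydroxypiperidin-1-yl in place of (4-butylpiperazin-1-yl)methyl gives a 36-fold lower number from compound 1 to compound 3 (1.56 log units; beyond the scatter), the first step that isolates a change at one place. The leaving group has 11 heavy atoms, two ring nitrogens and no hydrogen-bond donor, while the entering group has 7 heavy atoms, one ring nitrogen, one oxygen and one hydrogen-bond donor, so the size of the step belongs to this whole exchange and not to any one part of it. Nothing at hand links the step to a cause.

The compounds shown leave open how much of the step follows the hydroxyl group, the loss of the butyl group, the second ring nitrogen or the change in chain length, as all of these change together in this one exchange. An unsubstituted piperidin-1-yl or a 4-methoxypiperidin-1-yl on the chain of compound 3, or a 4-butylpiperazin-1-yl on that same chain, would begin to separate these contributions.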